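The source may report more compounds than this note shows. Statements on the series, on what has been measured and on what is new or still open speak of the compounds shown alone.

Compound 1 `O=C(/C=C\c1ccccc1Cl)N1N=C(c2ccncc2)OC1c1c[nH]c2ccccc12` and compound 2 `O=C(/C=C\c1ccc(Cl)cc1)N1N=C(c2ccncc2)OC1c1c[nH]c2ccccc12` share one core and differ only in the ring that sits on the double-bonded chain. In an ADME assay on HeLa cells (Homo sapiens) for cytotoxicity, read by MTT assay, with a stated time of 72 h (on this read-out higher numbers stand for weaker inhibition of growth and lower numbers for stronger inhibition of growth), compound 1 gives > 30 ug/mL, a limit of the test rather than a number. In this assay compound 2 gives > 30 ug/mL, again a limit. The step that the two limits leave unreadable from compound 1 to compound 2 therefore cannot be read, since (the limit of > 30 ug/mL in this assay, at which 2 of the 2 values shown sit). Going by the values given here, compound 2 thus stands at the same limit as the only other known value, with nothing in the numbers to set it apart. Compound 3 `O=C(/C=C\c1ccc(Cl)cc1Cl)N1N=C(c2ccncc2)OC1c1c[nH]c2ccccc12` arises from compound 2 by chloro in place of hydrogen on an aromatic carbon. Among the compounds with values here, only that unreadable step bears on this change, so no shift beyond the scatter is expected. The step that the limit leaves unreadable from compound 2 to compound 3 is estimated to be small. Compound 3 is expected to give about 40 ug/mL, within 15 ug/mL to 100 ug/mL.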

Compound 3, concentration for 50% growth inhibition: 29.3 ug/mL
The estimate for compound 3 lay 1.4-fold (0.14 log units) above the measured number, and the stated range covers the measured number.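

Among the three compounds shown, only compound 3 gives a number rather than a limit in this assay, so the ring with two chloro groups is the first to come within the range of this test. Chloro in place of hydrogen gives an at least 1.0-fold lower number from compound 2 to compound 3 (0.01 log units; that floor lies within the scatter), and the same kind of change gives an at least 1.0-fold lower number from compound 1 to compound 3 (0.01 log units; that floor lies within the scatter). Neither step shows a real gain in growth inhibition, and each true size stays unknown because the other two compounds give only limits: the limit of > 30 ug/mL in this assay, at which 2 of the 3 values shown sit.

The compounds shown leave open whether an amine or a methoxy group on the same ring would give a lower number than chloro in this assay. They also leave open what a longer chain between this ring and the shared core would do.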